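A bicyclic heteroaryl in place of a catechol

A few compounds are considered here, and "the series" means these few. Any claim that something is new, unique, unknown or untested is made for them only; others in the source may bear on it.

Measured compounds:
compound 1, `CCOC(=O)C1=C(Nc2ccccc2)S/C(=C\c2ccc(O)c(O)c2)C1=O`: 30.7%
compound 2, `CCOC(=O)C1=C(Nc2cccc(F)c2)S/C(=C\c2ccc[nH]2)C1=O`: < 10%

Of the compounds shown here, two of this set have been measured in a functional assay on A549 cells (Homo sapiens) for inhibition, read by MTT assay, with a stated time of 72 h, tested at 10 uM; on this read-out lower numbers stand for less inhibition and higher numbers for more inhibition at the one concentration tested (going by the name of the read-out). Among the measured compounds shown here, compound 1 gives 30.7% in this assay, and this is the only number in the set. For compound 2 the assay reports (the limit of < 10% in this assay, at which 1 of the 2 values shown sits), which is a limit of the assay and not a number. For the measured compounds named here, compound 1 therefore stands alone as the one measured compound with a value on the scale, and no step between two measured compounds that differ in a single place is available.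

Compound 3 `CCOC(=O)C1=C(Nc2ccccc2)S/C(=C\c2cc3ccncc3[nH]2)C1=O` differs from compound 1 at one point: a group of 9 heavy atoms (7 carbon, 2 nitrogen; one five-membered aromatic ring with 1 hetero atom, one six-membered aromatic ring with 1 hetero atom) in place of a group of 8 heavy atoms (6 carbon, 2 oxygen; one six-membered aromatic ring of carbon only), on a double-bonded chain carbon bound to a double-bonded ring carbon. Going by the values given here, with no measured step of this kind to lean on, the size of the change can only be guessed. The loss of the 3,4-dihydroxyphenyl seen in compound 1 is expected to cost some inhibition, so the step of a number 12.7 percentage points lower from compound 1 to compound 3 (beyond the scatter) is expected to run downward, with a fair chance that only a limit is reported. Compound 3 is expected to give 18% in this assay, within 5% to 35%.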

Compound 3, a percentage reported as inhibition, at one concentration (the size of the read-out at that concentration, not a potency): 17.1%
Compound 3: middle estimate off by 0.9 percentage points, on the high side, and the stated range covers the measured number.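

In this assay, the exchange of the 3,4-dihydroxyphenyl for the group with one five-membered and one six-membered aromatic ring gives a number 13.6 percentage points lower from compound 1 to compound 3 (beyond the scatter). Among the compounds shown here, this is the first comparison in the set that isolates this place, on a double-bonded chain carbon bound to a double-bonded ring carbon, with the rest of the molecule held constant. It shows that the 3,4-dihydroxyphenyl is not needed for compound 3 to give a number on the scale rather than a limit, although the higher number of the pair stays with compound 1, and nothing shown here bears on why the number falls.

The compounds shown leave open which part of the change accounts for the step, since the two groups differ in ring make-up and in their counts of hydrogen-bond donors and acceptors at the same time. As far as these compounds go, a plain phenyl or a benzoic acid group at this place could help separate those features, and whether the step seen at this single concentration carries over to a full potency measurement also remains open.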